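Extending a Phenol Oxygen with a Carboxymethyl Group

The source may report more compounds than this note shows. Statements on the series, on what has been measured and on what is new or still open speak of the compounds shown alone.

Compound 1 `COc1ccc(C(c2ccccc2O)c2cccc3ccccc23)c(OC)c1OC`: 16600 nM
Compound 2 `COc1ccc(C(c2ccc(O)cc2)c2cccc3ccccc23)c(OC)c1OC`: 17500 nM

Of the compounds shown here, two have been measured in a functional assay on MCF7 cells (Homo sapiens) for inhibition, read by sulforhodamine B assay, with a stated time of 48 h; a higher number here means a weaker inhibitor, a lower number a stronger inhibitor. Compound 1 gives 16600 nM and compound 2 gives 17500 nM; both are weak inhibitors, and the step of a 1.1-fold higher number from compound 1 to compound 2 (0.02 log units; within the scatter) shows that moving the hydroxy from one position of the phenyl ring to another left the number essentially unchanged. Compound 2 therefore stands level with compound 1, and neither can be called the stronger of the two.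

Compound 3 `COc1ccc(C(c2ccc(OCC(=O)O)cc2)c2cccc3ccccc23)c(OC)c1OC` has not yet been measured. It differs from compound 2 by carboxymethyl in place of hydrogen on an oxygen on an aromatic ring. For the measured compounds named here, no measured step touches this kind of change: the only step available, from compound 1 to compound 2, concerns the position of the hydroxy and not its substitution, so it offers no direct guide. With a shared core that is already a weak inhibitor, the expectation is that compound 3 will also be weak, most likely with a number somewhat higher than that of compound 2, an expected step of a 1.4-fold higher number from compound 2 to compound 3 (0.15 log units; within the scatter). Compound 3 is thus estimated at 25000 nM, within a range from 8000 nM to 80000 nM.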

Compound 3, half-maximal inhibitory concentration: > 20000 nM
Compound 3: no number, only a limit; the forecaster's own chance of this, stated with the estimate: 20%; the middle value lies beyond the limit too.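

Compound 3, in this assay, gives > 20000 nM, which is a limit of the assay and not a number. The earlier pair spoke only to where the hydroxy sits, whereas this change replaces the hydrogen on the oxygen, and it gives no sign of a stronger inhibitor, with an at least 1.1-fold higher number from compound 2 to compound 3 (0.05 log units; that floor lies within the scatter) and, against the other hydroxy compound, an at least 1.2-fold higher number from compound 1 to compound 3 (0.08 log units; that floor lies within the scatter). Both steps are floors, so carboxymethyl at this oxygen may leave the number within the scatter or raise it much further, and the true size of neither step can be read because of a single limit: the limit of > 20000 nM in this assay, at which 1 of the 3 values shown sits.

The compounds shown leave open whether the carboxylic acid itself matters here or simply the added chain, a question that a methyl ester or an amide on the same oxygen could help to separate. They also leave open what a longer chain ending in the acid, or an amine in its place, would do to the number in this assay.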